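From Imidazolyl to Trifluoromethyl on a Shared Core

The source may report more compounds than this note shows. Statements on the series, on what has been measured and on what is new or still open speak of the compounds shown alone.

Among the compounds with values here, compound 3 `CS(=O)(=O)c1cc(C(=O)N=C(N)N)ccc1-n1ccnc1` gives 150 nM in a functional assay for inhibition of sodium/hydrogen exchanger (Oryctolagus cuniculus) (a higher number here means a weaker inhibitor, a lower number a stronger inhibitor), the highest number among the three compounds measured so far. Compound 1 `Cc1cc(-n2ccnc2)c(S(C)(=O)=O)cc1C(=O)N=C(N)N` gives 23 nM in this assay, and compound 2 `CS(=O)(=O)c1cc(C(=O)N=C(N)N)c(Cl)cc1-n1ccnc1` gives 130 nM. Replacing methyl by hydrogen produced a 6.5-fold higher number from compound 1 to compound 3 (0.81 log units; beyond the scatter), whereas replacing chloro by hydrogen produced a 1.2-fold higher number from compound 2 to compound 3 (0.06 log units; within the scatter).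

Compound 4 `CS(=O)(=O)c1cc(C(=O)N=C(N)N)ccc1C(F)(F)F` differs from compound 3 by trifluoromethyl in place of 1H-imidazol-1-yl on an aromatic carbon. Within the data shown here, none of the measured steps touches the imidazolyl; each varies only the methyl, chloro or hydrogen substituent while the imidazolyl and methylsulfonyl group stay in place. Among the measured compounds shown here, the data therefore offer no direct precedent for this change, and the only guidance is that the remaining part of compound 3 has given numbers within a modest span across the three analogues.

Compound 4 is accordingly estimated at 300 nM in this assay, within a range from 60 nM to 1500 nM. This estimate corresponds to an expected step of a 2.0-fold higher number from compound 3 to compound 4 (0.30 log units; within the scatter), towards a somewhat higher number but with wide uncertainty.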

Compound 4, half-maximal inhibitory concentration: 140 nM
For compound 4 the middle estimate is 2.1-fold (0.33 log units) above the measured one; the measured number falls inside the stated range.
By their numbers in this assay, from the lowest: compound 1; then compounds 2, 4 and 3 (each within the scatter of the next).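

In this assay, within the data shown here, the position ortho to a methylsulfonyl group, held by 1H-imidazol-1-yl in all the earlier compounds, now carries a different group, and trifluoromethyl in place of 1H-imidazol-1-yl gives a 1.1-fold lower number from compound 3 to compound 4 (0.03 log units; within the scatter). A five-membered aromatic ring with 2 hydrogen-bond acceptors and a group with no ring and no hydrogen-bond acceptors thus cannot be told apart here, so on this core neither the ring nor those acceptors is required for a number of this size. No measurement shown bears on why the two groups read alike.

Going by these compounds, it remains open whether trifluoromethyl would read the same in the presence of the methyl of compound 1, whose replacement by hydrogen gave a 6.5-fold higher number from compound 1 to compound 3 (0.81 log units; beyond the scatter). Also open, on these data alone, is how an amine, a carboxylic acid or a methoxy group would read at this position.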